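Ester-to-acid change on a weak dipeptidase series

A few compounds are considered here, and "the series" means these few. Any claim that something is new, unique, unknown or untested is made for them only; others in the source may bear on it.

Measured compounds:
compound 1 `CCCCc1nn(-c2ccccc2Cl)c(C(=O)OCC)c1Cc1ccc(-c2ccccc2-c2nn[nH]n2)cc1`: 250000 nM
compound 2 `CCCCc1nn(-c2ccccc2)c(C(=O)OCC)c1Cc1ccc(-c2ccccc2-c2nn[nH]n2)cc1`: 250000 nM

In an assay on isolated protein for inhibition of Dipeptidase 1 (Sus scrofa) (on this read-out higher numbers stand for weaker inhibition and lower numbers for stronger inhibition), compound 1 gives 250000 nM and stands level with compound 2, which gives 250000 nM in this assay. Within the data shown here, the one recorded step, no change at the digits printed from compound 1 to compound 2 (within the scatter), exchanges hydrogen for chloro on an aromatic carbon and leaves the read-out unchanged within the scatter.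

Compound 3 `CCCCc1nn(-c2ccccc2Cl)c(C(=O)O)c1Cc1ccc(-c2ccccc2-c2nn[nH]n2)cc1` has not yet been measured in this assay. It differs from compound 1 by hydrogen in place of ethyl on an oxygen next to a carbonyl group; read one bond further out, the change is ethoxycarbonyl to carboxy. Among the measured compounds shown here, no measured step touches this position: the only step available concerns the aromatic chloro and says nothing about the ester oxygen. The expectation for compound 3 therefore rests on the value of compound 1 alone, 250000 nM, with no basis for a shift in either direction beyond the scatter.

On that basis compound 3 is expected to give about 250000 nM in this assay, with a plausible range from 60000 nM to 600000 nM, corresponding to an expected step of no change at the digits printed from compound 1 to compound 3 (within the scatter).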

Compound 3, inhibition constant: 350000 nM
Beside the measured number, compound 3's estimate is 1.4-fold (0.15 log units) below it, within the range that was stated.
By their numbers in this assay, from the lowest: compounds 1, 2 and 3 (each within the scatter of the next).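

Among these compounds, replacing ethoxycarbonyl with carboxy gives the first reading at this position: in this assay the step is a 1.4-fold higher number from compound 1 to compound 3 (0.15 log units; within the scatter) and so does not go beyond the scatter. The ethyl on an oxygen next to a carbonyl group can therefore be exchanged for hydrogen without a measurable shift in the read-out, which the chloro step alone could not show. No measurement available here bears on why this exchange leaves the read-out within the scatter.

With compound 3 at 350000 nM and the two esters no better placed, neither the ethyl nor the aromatic chloro has yet separated one compound from another, so the series offers no lead on which changes matter. Still open, from the compounds shown here alone, is whether an amide or a hydroxamic acid in place of the carboxy would move the read-out beyond the scatter, and whether the carboxy compound carrying hydrogen instead of the aromatic chloro would stand with compound 3.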